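Azido for Chloro on a Fused Core: Cytotoxicity Outlook

A few compounds are considered here, and "the series" means these few. Any claim that something is new, unique, unknown or untested is made for them only; others in the source may bear on it.

Measured so far in a functional assay on HeLa cells (Homo sapiens) for cytotoxicity, read by neutral red uptake, with a stated time of 3 days; on this read-out higher numbers stand for weaker inhibition and lower numbers for stronger inhibition:
compound 1 `CCCCc1c(F)c(N)c2c(=O)cc(-c3ccc(N)c(F)c3)oc2c1F` — reported only as the limit > 100000 nM
compound 2 `Nc1ccc(-c2cc(=O)c3c(N)c(F)c(Cl)c(F)c3o2)cc1F` — reported only as the limit > 100000 nM

Compound 2 therefore stands at the edge of what this assay reports, not at a number. Among the compounds with values here, the single measured step, a step that the two limits leave unreadable from compound 1 to compound 2, cannot be sized because the limit of > 100000 nM in this assay, at which 2 of the 2 values shown sit, hides any difference between the two compounds.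

Compound 3 `[N-]=[N+]=Nc1c(F)c(N)c2c(=O)cc(-c3ccc(N)c(F)c3)oc2c1F` differs from compound 2 by azido in place of chloro on an aromatic carbon. Within the data shown here, the only step that bears on this change is the unreadable one, so no direction beyond the scatter can be foreseen; the step that the limit leaves unreadable from compound 2 to compound 3 is expected to be essentially none. Compound 3 is estimated at 150000 nM, with a range from 40000 nM to 600000 nM, most likely reported again only as a limit.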

Compound 3, half-maximal inhibitory concentration: 1200 nM
Compound 3: middle estimate off by 130-fold (2.10 log units), on the high side, and the stated range ends above it.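

In this assay, this aromatic carbon, ortho to two fluoro groups, now proves able to change the read-out: azido in place of chloro gives an at least 83-fold lower number from compound 2 to compound 3 (1.92 log units; beyond the scatter) and azido in place of butyl gives an at least 83-fold lower number from compound 1 to compound 3 (1.92 log units; beyond the scatter) in the same series. Compound 1 and compound 2 could not show this, and the step between them cannot be read: the limit of > 100000 nM in this assay, at which 2 of the 3 values shown sit.

Going by these compounds, whether azido is unusual here remains open. A nitrile or a bromo group on the same carbon would show whether other replacements also bring the number down.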